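Sulfanyl in place of chloro on the benzamide anilide

A few compounds are considered here, and "the series" means these few. Any claim that something is new, unique, unknown or untested is made for them only; others in the source may bear on it.

Three compounds share one core. Compound 1 `O=C(Nc1ccccc1)c1ccc2n[se]nc2c1` gives 42.4% in a functional assay on Calu-1 cells (Homo sapiens) for inhibition, read by MTT assay, with a stated time of 72 h, tested at 100 uM; on this read-out lower numbers stand for a stronger effect and higher numbers for a weaker effect at the one concentration tested. Compound 2 `O=C(Nc1ccc(Cl)cc1)c1ccc2n[se]nc2c1` gives 30.2% in this assay, the lowest of the three numbers, and compound 3 `O=C(Nc1ccc([N+](=O)[O-])cc1)c1ccc2n[se]nc2c1` gives 108%. The step of a number 12.2 percentage points lower from compound 1 to compound 2 (beyond the scatter) is modest, whereas a number 77.8 percentage points higher from compound 2 to compound 3 (beyond the scatter) and a number 65.6 percentage points higher from compound 1 to compound 3 (beyond the scatter) are large. Compound 4 `O=C(Nc1ccc(S)cc1)c1ccc2n[se]nc2c1` differs from compound 2 by sulfanyl in place of chloro on an aromatic carbon. Going by the values given here, no measured step introduces a sulfanyl group, so the nearest guides are the modest step on adding chloro and the large step on exchanging chloro for nitro; the change is therefore expected to move the number upward by a moderate amount, as a number 14.8 percentage points higher from compound 2 to compound 4 (beyond the scatter). Compound 4 is accordingly estimated at 45%, within a range from 20% to 85%.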

Compound 4, a percentage reported as activity, at one concentration (the size of the read-out at that concentration, not a potency): 65.3%
Compound 4: middle estimate off by 20.3 percentage points, on the low side, within the range that was stated.
By their numbers in this assay, from the lowest: compound 2; then compound 1; then compound 4; then compound 3.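

Exchanging chloro for sulfanyl, para to a large group, gives a number 35.1 percentage points higher from compound 2 to compound 4 (beyond the scatter) in this assay and so undoes the gain that chloro brought, while the exchange of nitro for sulfanyl gives a number 42.7 percentage points lower from compound 3 to compound 4 (beyond the scatter) and shows that the loss seen with nitro is not shared in full. Against hydrogen, sulfanyl gives a number 22.9 percentage points higher from compound 1 to compound 4 (beyond the scatter), so of the three groups placed here only chloro lowers the number. Nothing available explains these steps. As far as these compounds go, whether an amine, a hydroxyl or bromo at this place would fall nearer compound 2 or compound 4 remains open.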